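Aryl Exchange on a Shared Core: Cytotoxicity Outlook for Compound 3

This account rests on a few compounds, and the source may have more. Where it says the series, first, only, none or still open, it means among the compounds named here.

Compound 1 `C=CCOc1cc(OC)c(C(=O)/C=C/c2ccccc2F)c(OCC=C)c1` — 16300 nM
Compound 2 `C=CCOc1cc(OC)c(C(=O)/C=C/c2cccc(OC)c2)c(OCC=C)c1` — 142000 nM

Of the compounds shown here, two have been measured in an ADME assay on Vero cells (Chlorocebus sabaeus) for cytotoxicity, read by MTT assay; a higher number here means a weaker inhibitor, a lower number a stronger inhibitor. Going by the values given here, compound 2 stands highest of the two numbers; its nearest neighbour is compound 1, and the only measured step, an 8.7-fold higher number from compound 1 to compound 2 (0.94 log units; beyond the scatter), is the one that bears on the change now considered, since it too exchanges the aryl group at the same place. Compound 3 `C=CCOc1cc(OC)c(C(=O)/C=C/c2ccc(Cl)cc2)c(OCC=C)c1` differs from compound 2 as follows: 4-chlorophenyl in place of 3-methoxyphenyl on a double-bonded chain carbon bound to a double-bonded chain carbon.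

Because compound 1 gives 16300 nM with an aryl bearing a halogen, a return to an aryl bearing a halogen is expected to give a lower number in this assay, a modest step of a 3.6-fold lower number from compound 2 to compound 3 (0.55 log units; beyond the scatter), though the move from 2-fluorophenyl to 4-chlorophenyl itself is not covered by any measured step. Compound 3 is therefore estimated at 40000 nM, with a range from 14000 nM to 120000 nM.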

Compound 3, half-maximal inhibitory concentration: 10400 nM
Compound 3: the middle estimate sits 3.8-fold (0.59 log units) above what was measured; measured number below the stated range.
By their numbers in this assay, from the lowest: compounds 3 and 1 (each within the scatter of the next); then compound 2.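

In this assay, the aryl group on a double-bonded chain carbon bound to a double-bonded chain carbon again moves the number, and 4-chlorophenyl in place of 3-methoxyphenyl gives a 14-fold lower number from compound 2 to compound 3 (1.14 log units; beyond the scatter) at this position. Going by these compounds alone, the exchange of 2-fluorophenyl for 4-chlorophenyl, which had no earlier step, gives a 1.6-fold lower number from compound 1 to compound 3 (0.20 log units; within the scatter) and so leaves the two halogen-bearing aryl compounds indistinguishable, with compound 2 alone at the high end of the three. Nothing at hand explains why the numbers fall this way.

Still open, as far as these compounds go, is whether the halogen itself matters or whether the drop comes from losing the methoxy group, as 3-methoxyphenyl is the only aryl here without a halogen. Plain phenyl, or a phenyl bearing an amine or a carboxylic acid, would show how far this pattern extends.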